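Methylamino for methoxy on the carbonyl of compound 1

The source may hold more compounds than are shown below. What is called first, only, known or untested is meant among the compounds shown, and "the series" means these compounds.

Measured so far:
- compound 1, `COC(=O)c1cnc(C(=O)CCc2ccc(COc3ccccc3)cc2)o1`, an assay for inhibition of Fatty-acid amide hydrolase 1 (Rattus norvegicus); on this read-out lower numbers stand for stronger inhibition and higher numbers for weaker inhibition: 1.6 nM
- compound 2, `O=C(O)c1cccc(-c2cnc(CCCc3ccc(-c4ccccc4)cc3)o2)n1`, this assay: 10000 nM
- compound 3, `COC(=O)c1cnc(C(=O)CCc2ccc(Oc3ccccc3)cc2)o1`, this assay: 1.7 nM

Compound 1 gives the lowest of the three numbers. Compound 3 sits beside it: a 1.1-fold higher number from compound 1 to compound 3 (0.03 log units; within the scatter). Among the compounds with values here, compound 2 lies far from both, its value being the highest of the set; no single-point step links it to compound 1, so only the two values themselves speak.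

Compound 4, `CNC(=O)c1cnc(C(=O)CCc2ccc(COc3ccccc3)cc2)o1`, is the next candidate. Its difference from compound 1 is methylamino in place of methoxy on a carbonyl carbon whose other neighbour is an aromatic carbon; cut one bond further out, methoxycarbonyl becomes methylcarbamoyl.

Within the data shown here, none of the measured steps touches this carbonyl: the one step at hand concerns the phenoxy versus phenoxymethyl end of the molecule and stays within the scatter. The carbonyl substituent is therefore untested in this series, and the change cannot be anchored to a measured step. With nothing to point either way, compound 4 is expected to stay close to compound 1, with the estimated step being a 3.1-fold higher number from compound 1 to compound 4 (0.49 log units; beyond the scatter). The estimate for compound 4 in this assay is 5 nM, within 1 nM to 25 nM.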

Compound 4, inhibition constant: 3.6 nM
Compound 4: the middle estimate sits 1.4-fold (0.14 log units) above what was measured, within the range that was stated.
By their numbers in this assay, from the lowest: compounds 1 and 3 (each within the scatter of the next); then compound 4; then compound 2.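

In this assay, within the data shown here, the change from methoxycarbonyl to methylcarbamoyl gives the first measured step at this carbonyl carbon (a 2.3-fold higher number from compound 1 to compound 4 (0.35 log units; beyond the scatter)), a modest rise in the number, unlike the step at the phenoxymethyl end, which stayed within the scatter. Methoxycarbonyl is not essential for strong inhibition in this series: compound 4, with methylamino on the carbonyl, still gives 3.6 nM. No measurement available here bears on what lies behind this step.

Still open, on these data alone, is how a carboxylic acid, a primary carboxamide or a dimethylamino group on the same carbonyl carbon would compare with methoxy and methylamino. As far as these compounds go, it is also open whether the step carries over to the phenoxy analogue, compound 3, since methylcarbamoyl appears here only with the phenoxymethyl end.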